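Amide-to-oxadiazole exchange on the cyclopentane of compound 2

A few compounds are considered here, and "the series" means these few. Any claim that something is new, unique, unknown or untested is made for them only; others in the source may bear on it.

Among the measured compounds shown here, compound 1 `Clc1nn(-c2ccc3ncccc3c2)c2nc(Nc3cnn(C4CCNCC4)c3)ncc12` and compound 2 `COCCC(=O)N[C@@H]1CC[C@@H](Nc2ncc3c(Br)nn(-c4ccc5ncccc5c4)c3n2)C1` are the two measured members. In an assay on isolated protein for inhibition of eIF-2-alpha kinase GCN2 (Homo sapiens) (on this read-out higher numbers stand for weaker inhibition and lower numbers for stronger inhibition), compound 1 gives 5 nM. In this assay compound 2 gives 74 nM, the highest of the two numbers; the gap to compound 1 lies beyond the scatter, and as the two compounds differ in more than one place, no single change can be tied to it. Compound 3 `COCc1noc([C@@H]2CC[C@@H](Nc3ncc4c(Br)nn(-c5ccc6ncccc6c5)c4n3)C2)n1` follows from compound 2 by one change: a group of 8 heavy atoms (4 carbon, 2 nitrogen, 2 oxygen; one five-membered aromatic ring with 3 hetero atoms) in place of a group of 7 heavy atoms (4 carbon, 1 nitrogen, 2 oxygen; no ring), on a saturated ring carbon. For the measured compounds named here, no measured pair shows what such an exchange does, so the size of the step can only be estimated. The step of a 1.4-fold higher number from compound 2 to compound 3 (0.13 log units; within the scatter) is expected to be small, toward a slightly higher number, and not clearly beyond the scatter. Compound 3 is therefore estimated at 100 nM in this assay, with a range from 30 nM to 400 nM.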

Compound 3, half-maximal inhibitory concentration: 106 nM
Beside the measured number, compound 3's estimate is 1.1-fold (0.03 log units) below it; the measured number falls inside the stated range.
By their numbers in this assay, from the lowest: compound 1; then compounds 2 and 3 (each within the scatter of the next).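

On a saturated ring carbon of the five-membered non-aromatic ring, the five-membered aromatic ring with 3 hetero atoms in place of ((2-methoxyethyl)carbonyl)amino gives a 1.4-fold higher number from compound 2 to compound 3 (0.16 log units; within the scatter) in this assay, so the two values cannot be told apart. In this one pair, the amide hydrogen and the open chain of compound 2 are therefore not required to keep the read-out within the scatter. No measurement on these compounds speaks to the reason for this result.

On these data alone, whether an amine, a carboxylic acid or a longer chain on the entering ring would stay within the scatter of compound 3 remains open. Compound 1 differs from compound 2 in more than one place, so its lower number remains unassigned to any single change.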